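Bromo in place of trifluoromethyl on the pendant phenyl

The compounds below may be only part of what the source reports. "The series", "measured", "known", "first", "only" and "open" are said of these compounds alone.

Compound 1 `C=C1C[C@]23C[C@@]1(O)CC[C@H]2c1ccc(O)c(C)c1[C@@H]3Cn1cc(-c2ccc(C(F)(F)F)cc2)nn1` is read in a functional assay on SMMC-7721 cells (Homo sapiens) for cytotoxicity, read by MTT assay, with a stated time of 4 days; a lower number here means a stronger inhibitor, a higher number a weaker inhibitor. In this assay compound 1 gives > 20000 nM, which is a limit of the assay and not a number. Compound 1 thus stands at the limit of > 20000 nM in this assay, at which 1 of the 2 values shown sits. Going by the values given here, the one measured neighbour, compound 2 `C=C1C[C@]23C[C@@]1(O)CC[C@H]2c1cc(Br)c(O)c(C)c1[C@@H]3Cn1cc(-c2ccc(C(F)(F)F)cc2)nn1`, gives 12800 nM in this assay, and the step of an at least 1.5-fold lower number from compound 1 to compound 2 (0.19 log units; that floor lies within the scatter) goes with bromo in place of hydrogen on an aromatic carbon of the shared core.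

Compound 3 `C=C1C[C@]23C[C@@]1(O)CC[C@H]2c1ccc(O)c(C)c1[C@@H]3Cn1cc(-c2ccc(Br)cc2)nn1` differs from compound 1 by bromo in place of trifluoromethyl on an aromatic carbon. Among the compounds with values here, no measured step covers this change: the step from compound 1 to compound 2 alters the core, not the pendant phenyl, and gives no guide here. For compound 3 the expected step is a step that the limit leaves unreadable from compound 1 to compound 3 in this assay, with a fair chance that only a limit is returned. The estimate for compound 3 is 25000 nM, within 10000 nM to 60000 nM.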

Compound 3, half-maximal inhibitory concentration: > 20000 nM
Compound 3 gave a limit, no number (the forecaster's own chance of this, stated with the estimate: 60%); the middle value lies beyond the limit too.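

No step can be read between compound 1 and compound 3, since each returns only a limit of the assay in this assay and no number: the limit of > 20000 nM in this assay, at which 2 of the 3 values shown sit.

The compounds shown leave open whether 4-(trifluoromethyl)phenyl to 4-bromophenyl changes the read-out in this assay at all.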